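A few compounds are considered here, and "the series" means these few. Any claim that something is new, unique, unknown or untested is made for them only; others in the source may bear on it.

Measured compounds:
compound 1, `C[S+]([O-])c1ccc(CSc2nc(-c3ccc(Br)cc3)c(-c3ccncc3)[nH]2)cc1`, 820 nM
compound 2, `CS(=O)(=O)c1ccc(CSc2nc(-c3ccc(Br)cc3)c(-c3ccncc3)[nH]2)cc1`, 640 nM
compound 3, `C[S+]([O-])c1ccc(CSc2nc(-c3ccccc3)c(-c3ccncc3)[nH]2)cc1`, 840 nM

All three were tested in a functional assay (Homo sapiens) for inhibition; on this read-out lower numbers stand for stronger inhibition and higher numbers for weaker inhibition. They share one core; compound 3 differs from compound 1 by hydrogen in place of bromo on an aromatic carbon, and their numbers lie within the scatter of each other: a 1.0-fold higher number from compound 1 to compound 3 (0.01 log units; within the scatter). Compound 2 differs from compound 1 by a group of 4 heavy atoms (1 carbon, 2 oxygen, 1 sulfur; no ring) in place of a group of 3 heavy atoms (1 carbon, 1 oxygen, 1 sulfur; no ring), on an aromatic carbon, giving a 1.3-fold lower number from compound 1 to compound 2 (0.11 log units; within the scatter). Compound 4, `CS(=O)(=O)c1ccc(CSc2nc(-c3ccccc3)c(-c3ccncc3)[nH]2)cc1`, has not yet been measured. It stands to compound 3 as compound 2 stands to compound 1: the change is a group of 4 heavy atoms (1 carbon, 2 oxygen, 1 sulfur; no ring) in place of a group of 3 heavy atoms (1 carbon, 1 oxygen, 1 sulfur; no ring), on an aromatic carbon, the same change at the same place. Because the step of a 1.3-fold lower number from compound 1 to compound 2 (0.11 log units; within the scatter) stayed within the scatter, the expected step of a 1.3-fold lower number from compound 3 to compound 4 (0.10 log units; within the scatter) is likewise small. For compound 4 the estimate in this assay is 660 nM, with a likely range from 320 nM to 1400 nM.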

Compound 4, half-maximal inhibitory concentration: 1700 nM
Compound 4: middle estimate off by 2.6-fold (0.41 log units), on the low side; the whole stated range lies below it.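

In this assay, bringing in the methylsulfonyl group on the core without bromo gives a 2.0-fold higher number from compound 3 to compound 4 (0.31 log units; beyond the scatter), and hydrogen in place of bromo among the methylsulfonyl compounds gives a 2.7-fold higher number from compound 2 to compound 4 (0.42 log units; beyond the scatter). This shows neither that the methylsulfonyl change behaves differently on the two cores nor that it carries over unchanged: the same change on two cores in this assay, a 1.3-fold lower number (0.11 log units; within the scatter) from compound 1 to compound 2 and a 2.0-fold higher number (0.31 log units; beyond the scatter) from compound 3 to compound 4, 2.6-fold (0.41 log units) apart, within the scatter of two such steps. The same holds for hydrogen in place of bromo: the same change on two cores in this assay, a 1.0-fold higher number (0.01 log units; within the scatter) from compound 1 to compound 3 and a 2.7-fold higher number (0.42 log units; beyond the scatter) from compound 2 to compound 4, 2.6-fold (0.41 log units) apart, within the scatter of two such steps.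

These four compounds leave open how other groups would behave at the place taken by methylsulfonyl, such as an amine or a carboxylic acid. They also leave open whether chloro in place of bromo would follow the same course.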